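The compounds below may be only part of what the source reports. "The series", "measured", "known", "first", "only" and "open" are said of these compounds alone.

Of the compounds shown here, three have so far been measured in an assay for inhibition of transient receptor potential cation channel subfamily V member 1 (Rattus norvegicus), with a stated time of 10 min; on this read-out lower numbers stand for stronger inhibition and higher numbers for weaker inhibition. Compound 1 `CC(C)(C)c1ccc(CCC/N=C(\S)NCc2ccc(NS(C)(=O)=O)c(F)c2)cc1` gives 2000 nM. Compound 2 `CC(C)(C)c1cc(C/N=C(\S)NCc2ccc(NS(C)(=O)=O)c(F)c2)cc(C(C)(C)C)c1` gives 200 nM. Compound 3 `CC(C)(C)c1ccc(C/N=C(\S)NCc2ccc(NS(C)(=O)=O)c(C(=O)NO)c2)cc1` gives > 30000 nM.

The value for compound 3 is a limit of this assay, not a number; compound 3 sits at the limit of > 30000 nM in this assay, at which 1 of the 3 values shown sits. So where compound 3 stands can be said only in part: its inhibition is weaker than that of either other compound, but how much weaker is not known.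

Compound 4 `CC(C)(C)c1ccc(C/N=C(\S)NCc2ccc(NS(C)(=O)=O)c(I)c2)cc1` has not yet been measured in this assay. It differs from compound 3 in one place: iodo in place of hydroxycarbamoyl on an aromatic carbon. Among the measured compounds shown here, no step between measured compounds covers this change, so the direction can only be read from the fact that compound 1 gives 2000 nM and compound 2 gives 200 nM while neither carries a hydroxycarbamoyl group. On that basis a large step toward stronger inhibition, well beyond the scatter, is expected for an at least 60-fold lower number from compound 3 to compound 4 (1.77 log units; beyond the scatter). In this assay compound 4 is estimated at 500 nM, with a range from 80 nM to 4000 nM.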

Compound 4, half-maximal inhibitory concentration: 41 nM
Estimate against measurement, compound 4: 12-fold (1.09 log units) above, outside the stated range (below it).
By their numbers in this assay, from the lowest: compound 4; then compound 2; then compound 1. At a limit, above all of these: compound 3.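

In this assay, among the compounds shown here, putting iodo in place of hydroxycarbamoyl on the aromatic carbon ortho to a methanesulfonamido group gives an at least 730-fold lower number from compound 3 to compound 4 (2.86 log units; beyond the scatter), the first step at this place, and it shows that this one position alone can move the number far beyond the scatter. The value of compound 3 is a limit of the assay, not a number: the limit of > 30000 nM in this assay, at which 1 of the 4 values shown sits. The size of the step is therefore a minimum, and its true size cannot be read.

On these data alone, how a chloro, a bromo or a methyl group, or a plain hydrogen, at this place on the core of compound 4 would read against iodo stays open. Also open, as far as these compounds go, is whether the lower number comes with iodo itself or with the departure of hydroxycarbamoyl.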